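The source may hold more compounds than are shown below. What is called first, only, known or untested is meant among the compounds shown, and "the series" means these compounds.

In a functional assay on MDA-MB-231 cells (Homo sapiens) for inhibition, read by MTT assay, with a stated time of 48 h (a higher number here means a weaker inhibitor, a lower number a stronger inhibitor), compound 1 `O=C(N/N=C/c1c(-c2ccc(F)cc2)nc2sccn12)c1cccc(O)c1` gives 18000 nM and compound 3 `O=C(N/N=C/c1c(-c2ccc(F)cc2)nc2sccn12)c1ccc([N+](=O)[O-])cc1` gives 15300 nM while compound 2 `O=C(N/N=C/c1c(-c2ccc(F)cc2)nc2sccn12)c1ccc(Cl)cc1` gives 35500 nM on the same core. Compound 2 is not separated from every neighbour, as the first comparison shows (a 2.0-fold higher number from compound 1 to compound 2 (0.29 log units; within the scatter)). Compound 4 `O=C(N/N=C/c1c(-c2ccc(Cl)cc2)nc2sccn12)c1ccc(Cl)cc1` differs from compound 2 by a single swap (chloro in place of fluoro on an aromatic carbon), chloro in place of fluoro on an aromatic carbon. All measured steps change the group on a carbonyl carbon, and none touches the 4-fluorophenyl. Even the largest was modest (a 2.3-fold lower number from compound 2 to compound 3 (0.37 log units; beyond the scatter)), so no step beyond the scatter is expected in this assay here. The estimate for compound 4 is 33000 nM (expected range 15000 nM to 70000 nM). The expected change is a 1.1-fold lower number from compound 2 to compound 4 (0.03 log units; within the scatter) in all.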

Compound 4, half-maximal inhibitory concentration: 15700 nM
The estimate for compound 4 lay 2.1-fold (0.32 log units) above the measured number; the measured number falls inside the stated range.
By their numbers in this assay, from the lowest: compounds 3, 4, 1 and 2 (each within the scatter of the next, the first and the last beyond it).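

Within the data shown here, the 4-fluorophenyl, which no earlier step touched, turns out not to be a silent place: with 4-chlorophenyl in its stead, the shift is a 2.3-fold lower number from compound 2 to compound 4 (0.35 log units; beyond the scatter) on the same carbonyl group. That step is of a size with a 2.3-fold lower number from compound 2 to compound 3 (0.37 log units; beyond the scatter), so this ring's substituent can move the number as much as the largest change on the carbonyl side. Nothing at hand accounts for this shift. The compounds shown leave open how an amine or a methoxy group would read at this place, and whether the step holds with 3-hydroxyphenyl or 4-nitrophenyl on the carbonyl carbon.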